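A few compounds are considered here, and "the series" means these few. Any claim that something is new, unique, unknown or untested is made for them only; others in the source may bear on it.

Measured so far:
compound 1 `COc1ccc(C(=O)Nc2cccc(-c3oc4cc(-c5ccc(F)cc5)ccc4c(=O)c3O)c2)cc1` — 6250 nM in a functional assay on MCF7 cells (Homo sapiens) for antiproliferative activity, read by CCK-8 assay, with a stated time of 72 h; a higher number here means a weaker inhibitor, a lower number a stronger inhibitor
compound 2 `O=C(Nc1cccc(-c2oc3cc(-c4ccc(F)cc4)ccc3c(=O)c2O)c1)c1ccc(Cl)cc1` — 4730 nM in this assay

Within the data shown here, compound 2 shows the lowest of the two numbers, and the only nearby point is compound 1, with a 1.3-fold lower number from compound 1 to compound 2 (0.12 log units; within the scatter) separating them. Compound 3 `O=C(Nc1cccc(-c2oc3cc(-c4ccc(F)cc4)ccc3c(=O)c2O)c1)c1ccc(F)cc1F` carries the change (2,4-difluorophenyl in place of 4-chlorophenyl on a carbonyl carbon). Among the measured compounds shown here, the one measured step bears on this only loosely, since it swapped substituents on the same ring and stayed within the scatter, so no movement beyond the scatter is expected here either. The estimate for compound 3 is 4500 nM, with a range of 1800 nM to 11000 nM, which would mean an expected step of a 1.1-fold lower number from compound 2 to compound 3 (0.02 log units; within the scatter).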

Compound 3, half-maximal inhibitory concentration: 13500 nM
Compound 3: the middle estimate sits 3.0-fold (0.48 log units) below what was measured, and the stated range ends below it.
By their numbers in this assay, from the lowest: compounds 2 and 1 (each within the scatter of the next); then compound 3.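

At this position on a carbonyl carbon, the aromatic group does move the number in this assay: with 2,4-difluorophenyl entering there is a 2.9-fold higher number from compound 2 to compound 3 (0.46 log units; beyond the scatter) and also a 2.2-fold higher number from compound 1 to compound 3 (0.33 log units; beyond the scatter) in the same direction. Both steps lie beyond the scatter, while the swap between 4-methoxyphenyl and 4-chlorophenyl did not, so this place is not indifferent to every aromatic replacement. No evidence at hand accounts for this shift.

The compounds shown cannot separate the entry of two fluorines from the departure of the chlorine or methoxy group. From the compounds shown here alone, how a 4-aminophenyl or 4-carboxyphenyl group would read at this place also stays open.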